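Thioether series: aromatic branched substituent replacing cyclohexyl

The source may hold more compounds than are shown below. What is called first, only, known or untested is meant among the compounds shown, and "the series" means these compounds.

Measured compounds:
compound 1 `OC[C@H]1O[C@@H](n2cnc3c(SCC4CCCCC4)ncnc32)[C@H](O)[C@@H]1O` gives 1550 nM in an assay on isolated protein for binding affinity to Equilibrative nucleoside transporter 1 (Homo sapiens); on this read-out lower numbers stand for stronger inhibition and higher numbers for weaker inhibition;
compound 2 `OC[C@H]1O[C@@H](n2cnc3c(SC4CCCCC4)ncnc32)[C@H](O)[C@@H]1O` gives 6310 nM in this assay.

Within the data shown here, compound 2 has the higher of the two numbers; the one step recorded is a 4.1-fold higher number from compound 1 to compound 2 (0.61 log units; beyond the scatter). Compound 3 `CC(C)(Sc1ncnc2c1ncn2[C@@H]1O[C@H](CO)[C@@H](O)[C@H]1O)c1ccccc1` carries 1-methyl-1-phenylethyl in place of cyclohexyl on a sulfur. Among the measured compounds shown here, only that single step bears on this change, and it concerns a different pair of groups, so direct guidance is thin. A modest shift in either direction is plausible; a number near compound 2, perhaps somewhat lower, is expected for compound 3, i.e. a 1.6-fold lower number from compound 2 to compound 3 (0.20 log units; within the scatter). The estimate for compound 3 in this assay is 4000 nM, within 1000 nM to 16000 nM.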

Compound 3, half-maximal inhibitory concentration: 21400 nM
The estimate for compound 3 lay 5.4-fold (0.73 log units) below the measured number; measured number above the stated range.
By their numbers in this assay, from the lowest: compound 1; then compound 2; then compound 3.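

In this assay, this position on the sulfur does not accept the aromatic branched group well: 1-methyl-1-phenylethyl in place of cyclohexyl gives a 3.4-fold higher number from compound 2 to compound 3 (0.53 log units; beyond the scatter). Against the cyclohexylmethyl group the same substituent gives a 14-fold higher number from compound 1 to compound 3 (1.14 log units; beyond the scatter), so compound 3 carries the weakest inhibition of the three, with both steps beyond the scatter. No measurement at hand accounts for this rise.

From the compounds shown here alone, whether the rise goes with the phenyl ring or with the branching stays open. A benzyl group on the sulfur would help separate the two.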